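Ether chain length on the shared core: working notes

The source may hold more compounds than are shown below. What is called first, only, known or untested is meant among the compounds shown, and "the series" means these compounds.

Measured so far:
compound 1 `CC(C)Oc1cccc2ccc(N)nc12` — this assay: 437 nM
compound 2 `Nc1ccc2cccc(OC3CCCCCC3)c2n1` — this assay: 137 nM

In an assay on cells with melanin-concentrating hormone receptor 1 (Homo sapiens) as the target, read by radioligand binding (on this read-out higher numbers stand for weaker inhibition and lower numbers for stronger inhibition), compound 1 gives 437 nM, the highest of the two numbers available. Going by the values given here, compound 2 gives 137 nM, and the gap between the two lies beyond the usual scatter of repeated measurements; no single-point step between them is recorded, so only the two values themselves are taken from the pair.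

Compound 3 `CCCC(C)Oc1cccc2ccc(N)nc12` has not yet been measured. Against compound 1 the difference is ethyl in place of hydrogen on a saturated chain carbon, two bonds along the chain from an oxygen on an aromatic ring — cut one bond further out, the change reads isopropyl to 1-methylbutyl. With only two measured points, the direction of this step rests on the pair above: the larger ether substituent in compound 2 carries the lower number. A small step downward in number is therefore expected for compound 3, of a size at the edge of the scatter, with the step from compound 1 a 2.0-fold lower number from compound 1 to compound 3 (0.30 log units; within the scatter). The estimate for compound 3 is 220 nM, in the range 80 nM to 600 nM.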

Compound 3, half-maximal inhibitory concentration: 105 nM
Estimate against measurement, compound 3: 2.1-fold (0.32 log units) above; the range from low to high includes it.
By their numbers in this assay, from the lowest: compounds 3 and 2 (each within the scatter of the next); then compound 1.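

Working notes, continued. In this assay, ethyl in place of hydrogen on a saturated chain carbon, two bonds along the chain from an oxygen on an aromatic ring, gives a 4.2-fold lower number from compound 1 to compound 3 (0.62 log units; beyond the scatter), so this one change, read one bond further out as isopropyl to 1-methylbutyl, moves the number by more than the scatter, and the entering group carries no ring. Compound 2 at 137 nM and compound 3 at 105 nM lie within the scatter of each other, so the open-chain 1-methylbutyl ether of compound 3 and the ether substituent of compound 2 cannot be ordered on this read-out. No measurement shown here speaks to why the number moves at this position.

From the compounds shown here alone, a single step at this carbon gives one point and no trend, so it remains open whether a longer chain in place of the ethyl would lower the number further or raise it again. Going by these compounds, it also remains open how this position would respond to an amine or a carboxylic acid carried on the chain in place of plain carbon and hydrogen.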